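A few compounds are considered here, and "the series" means these few. Any claim that something is new, unique, unknown or untested is made for them only; others in the source may bear on it.

In a functional assay on MCF7 cells (Homo sapiens) for cytotoxicity, read by MTT assay, with a stated time of 24 h (on this read-out higher numbers stand for weaker inhibition and lower numbers for stronger inhibition), compound 1 `COc1cc2ncnc(Nc3ccc(F)c(Cl)c3)c2cc1OCCCSc1nc2ccccc2o1` gives 4050 nM, compound 2 `CCc1cc(Br)ccc1Nc1ncnc2cc(OC)c(OCCCSc3nc4ccccc4o3)cc12` gives 17300 nM and compound 3 `CCCCc1nc(Cl)c(C=O)n1CCCOc1cc2c(Nc3ccc(F)c(Cl)c3)ncnc2cc1OC` gives 5020 nM. Compound 3 lies within the scatter of compound 1 and has a lower number than compound 2, beyond the scatter. Compound 4 `CCCCc1nc(Cl)c(C=O)n1CCCOc1cc2c(Nc3ccc(Br)cc3CC)ncnc2cc1OC` carries 4-bromo-2-ethylphenyl in place of 3-chloro-4-fluorophenyl on a nitrogen on an aromatic ring of compound 3: 4-bromo-2-ethylphenyl in place of 3-chloro-4-fluorophenyl on a nitrogen on an aromatic ring. The same exchange has been measured once, a 4.3-fold higher number from compound 1 to compound 2 (0.63 log units; beyond the scatter), and that single pair is the main guide. The other measured step, a 1.2-fold higher number from compound 1 to compound 3 (0.09 log units; within the scatter), stays within the scatter and gives no size of its own. A modest step upward is therefore expected, a 4.0-fold higher number from compound 3 to compound 4 (0.60 log units; beyond the scatter). Compound 4 is estimated at 20000 nM, with an expected range of 9000 nM to 45000 nM.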

Compound 4, half-maximal inhibitory concentration: 6560 nM
Compound 4: middle estimate off by 3.0-fold (0.48 log units), on the high side; the measured number lies below the stated range.
By their numbers in this assay, from the lowest: compounds 1, 3 and 4 (each within the scatter of the next); then compound 2.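

In this assay, the exchange to 4-bromo-2-ethylphenyl on the nitrogen gives a 1.3-fold higher number from compound 3 to compound 4 (0.12 log units; within the scatter), so its size does not carry over from one chain group to the other: the same change on two cores in this assay, a 4.3-fold higher number (0.63 log units; beyond the scatter) from compound 1 to compound 2 and a 1.3-fold higher number (0.12 log units; within the scatter) from compound 3 to compound 4, 3.3-fold (0.51 log units) apart, beyond the scatter of two such steps. The exchange to 2-butyl-4-chloro-5-formyl-1H-imidazol-1-yl on the chain, within the scatter with 3-chloro-4-fluorophenyl, gives a 2.6-fold lower number from compound 2 to compound 4 (0.42 log units; beyond the scatter) with 4-bromo-2-ethylphenyl present: the same change on two cores in this assay, a 1.2-fold higher number (0.09 log units; within the scatter) from compound 1 to compound 3 and a 2.6-fold lower number (0.42 log units; beyond the scatter) from compound 2 to compound 4, 3.3-fold (0.51 log units) apart, beyond the scatter of two such steps.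

This dependence rests on four compounds only. Open, going by these compounds, is whether it holds with 3-ethynylphenyl on the nitrogen, or with a morpholine or a carboxylic acid in place of the chain groups.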